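The source may hold more compounds than are shown below. What is called first, only, known or untested is meant among the compounds shown, and "the series" means these compounds.

Among the measured compounds shown here, compound 2 `CCn1c(C(=O)OC(C)CCO)ccc1C(CC)(CC)c1ccc(OCC(=O)C(C)(C)C)c(C)c1` gives 380 nM in an assay on HL-60 cells for agonist activity at vitamin D3 receptor (Homo sapiens), read by microscopy, with a stated time of 96 h (a lower number here means that less compound is needed, a higher number that more compound is needed for the effect), the higher of the two numbers known so far; compound 1 `CCn1c(C(=O)NCCN(C)C)ccc1C(CC)(CC)c1ccc(OCC(=O)C(C)(C)C)c(C)c1` gives 77 nM in this assay. For the measured compounds named here, the one measured step, a 4.9-fold higher number from compound 1 to compound 2 (0.69 log units; beyond the scatter), changed the group on the carbonyl carbon. Compound 3 `CCn1c(C(=O)OCc2ccccn2)ccc1C(CC)(CC)c1ccc(OCC(=O)C(C)(C)C)c(C)c1` differs from compound 2 by (pyridin-2-yl)methyl in place of 3-hydroxy-1-methylpropyl on an oxygen next to a carbonyl group. Going by the values given here, no measured step changes the group on this oxygen, so the modest step already seen is only an indirect guide, and a step within the scatter in either direction is expected. Compound 3 is therefore expected to give about 300 nM, between 100 nM and 1000 nM, a step of a 1.3-fold lower number from compound 2 to compound 3 (0.10 log units; within the scatter).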

Compound 3, half-maximal effective concentration: > 50000 nM
Compound 3 was reported as a limit; the forecaster's own chance of this, stated with the estimate: 5%; at least 160-fold (2.22 log units) between middle value and limit.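

In this assay, the group on an oxygen next to a carbonyl group proves able to decide the result: (pyridin-2-yl)methyl in place of 3-hydroxy-1-methylpropyl gives an at least 130-fold higher number from compound 2 to compound 3 (2.11 log units; beyond the scatter). With (pyridin-2-yl)methoxy in place of (2-(dimethylamino)ethyl)amino on the carbonyl carbon, the gap is wider still, an at least 640-fold higher number from compound 1 to compound 3 (2.81 log units; beyond the scatter). Both steps rest on compound 3, whose value is a limit of the assay and not a number: the limit of > 50000 nM in this assay, at which 1 of the 3 values shown sits.

The ring entered as the hydroxyl left, so the compounds shown cannot say which of the two changes matters. A plain benzyl group or a longer hydroxyalkyl chain on this oxygen would help to separate them.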